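From 4-cyanophenyl to 3-acetylphenyl

A few compounds are considered here, and "the series" means these few. Any claim that something is new, unique, unknown or untested is made for them only; others in the source may bear on it.

In a functional assay on HCT-116 cells (Homo sapiens) for antiproliferative activity, read by MTT assay, with a stated time of 72 h (on this read-out lower numbers stand for stronger inhibition and higher numbers for weaker inhibition), compound 1 `C#Cc1cccc(NC(=O)CCc2cccc3c2B(O)OC3)c1` gives 3600 nM, compound 2 `O=C(CCc1cccc2c1B(O)OC2)Nc1cccc(-c2ccccc2)c1` gives 890 nM, and compound 3 `N#Cc1ccc(-c2cccc(NC(=O)CCc3cccc4c3B(O)OC4)c2)cc1` gives 410 nM, the lowest number of the three. Compound 4 `CC(=O)c1cccc(-c2cccc(NC(=O)CCc3cccc4c3B(O)OC4)c2)c1` differs from compound 3 by 3-acetylphenyl in place of 4-cyanophenyl on an aromatic carbon, with 3-acetylphenyl in place of 4-cyanophenyl on an aromatic carbon. Replacing ethynyl gave modest drops, a 4.0-fold lower number from compound 1 to compound 2 (0.61 log units; beyond the scatter) and an 8.8-fold lower number from compound 1 to compound 3 (0.94 log units; beyond the scatter), while adding cyano gave only a 2.2-fold lower number from compound 2 to compound 3 (0.34 log units; beyond the scatter). Going by the values given here, no acetyl compound has been measured, so the swap is expected to give up part of that last small gain, with no step beyond the scatter. The estimated change is a 1.5-fold higher number from compound 3 to compound 4 (0.17 log units; within the scatter). For compound 4, the estimated value is 600 nM, with an expected range of 250 nM to 1400 nM.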

Compound 4, half-maximal inhibitory concentration: 86 nM
For compound 4 the middle estimate is 7.0-fold (0.84 log units) above the measured one; measured number outside the range, below it.
By their numbers in this assay, from the lowest: compound 4; then compound 3; then compound 2; then compound 1.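

In this assay the substituted aryl group at this position is not a fixed gain, since 3-acetylphenyl gives a 4.8-fold lower number from compound 3 to compound 4 (0.68 log units; beyond the scatter) even though both groups count one hydrogen-bond acceptor. Acetyl on the phenyl ring gives a 10-fold lower number from compound 2 to compound 4 (1.01 log units; beyond the scatter) and turns a modest gain into a large one. Against ethynyl the new group gives a 42-fold lower number from compound 1 to compound 4 (1.62 log units; beyond the scatter) and stands lowest of the four.

Going by these compounds, whether the gain follows the acetyl or its placement stays open, since 3-acetylphenyl and 4-cyanophenyl differ in both. On these data alone, an amine or a carboxylic acid here also remains untested in these compounds. No measurement shown accounts for the gain.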